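Rat hepatocyte clearance notes: three measured, one pending

The source may hold more compounds than are shown below. What is called first, only, known or untested is meant among the compounds shown, and "the series" means these compounds.

Measured so far, in an ADME assay on cells (Hepatocyte, Rattus norvegicus) for metabolic stability; a higher number here means faster removal of the compound, a lower number slower removal:
- compound 1 `Cc1ccc2[nH]c(C(=O)N[C@H]3CN(S(=O)(=O)c4ccccc4)C[C@@H]3C(=O)NC[C@H]3CCCN3)cc2c1` gives 10 uL/min
- compound 2 `Cc1ccc2[nH]c(C(=O)N[C@H]3CN(S(=O)(=O)c4ccccc4)C[C@@H]3C(=O)NC[C@H]3CCCN3C)cc2c1` gives 21 uL/min
- compound 3 `Cc1ccc2[nH]c(C(=O)N[C@H]3CN(S(=O)(=O)c4ccccc4)C[C@@H]3C(=O)N[C@H]3CCCNC3)cc2c1` gives 7 uL/min

Compound 3 has the lowest of the three numbers. Its gap to compound 1 is small, a 1.4-fold lower number from compound 1 to compound 3 (0.15 log units; within the scatter), so the two cannot be ordered. Going by the values given here, the only steps in this assay that clear the scatter both involve compound 2: a 2.1-fold higher number from compound 1 to compound 2 (0.32 log units; beyond the scatter) and a 3.0-fold lower number from compound 2 to compound 3 (0.48 log units; beyond the scatter), each modest. All three measured steps change the amine carried on the amide-type nitrogen; none changes the acyl side.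

Compound 4 `O=C(N[C@H]1CN(S(=O)(=O)c2ccccc2)C[C@@H]1C(=O)N[C@H]1CCCNC1)c1cc(-c2ccccc2)on1` is the next compound. (5-phenyl-1,2-oxazol-3-yl in place of 5-methyl-1H-indol-2-yl on a carbonyl carbon). Among the compounds with values here, this is a change on the carbonyl carbon, a part of the molecule that no measured step touches, so none of the three steps bears directly on it, and the measured set gives no direction for it. With nothing to point either way, the expectation for the step is one that stays inside the usual scatter, a 1.1-fold higher number from compound 3 to compound 4 (0.06 log units; within the scatter), with a wide band around it. Compound 4 is therefore estimated at 8 uL/min in this assay, expected to fall between 3 uL/min and 22 uL/min.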

Compound 4, intrinsic clearance in a liver preparation (reported as CLH), per the amount of preparation that the assay uses: 6.8 uL/min
Beside the measured number, compound 4's estimate is 1.2-fold (0.07 log units) above it; the measured number falls inside the stated range.
By their numbers in this assay, from the lowest: compounds 4, 3 and 1 (each within the scatter of the next); then compound 2.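

In this assay, going by these compounds alone, the first change on the acyl side gives a 1.0-fold lower number from compound 3 to compound 4 (0.01 log units; within the scatter), so compound 3 and compound 4 cannot be told apart, and this carbonyl-carbon position accepts 5-phenyl-1,2-oxazol-3-yl in place of 5-methyl-1H-indol-2-yl with the piperidin-3-yl amide held constant. Within the data shown here, the exchange replaces a group with a hydrogen-bond donor and no acceptors by one with acceptors and no donor, and it also changes the five-membered aromatic ring, yet the read-out does not separate the pair; this single step is the only reading available for the position. Nothing at hand accounts for the closeness of the two numbers or assigns any part of it to the donor, the acceptors or the ring.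

Going by these compounds, it remains open whether the same exchange would read alike with the (1-methylpyrrolidin-2-yl)methyl amide of compound 2, the one amine in the set that stands clear of the others. Also open, on these data alone, is how this position would respond to a less similar group, such as a carboxylic acid or a saturated alkyl chain in place of 5-phenyl-1,2-oxazol-3-yl.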